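A few compounds are considered here, and "the series" means these few. Any claim that something is new, unique, unknown or untested is made for them only; others in the source may bear on it.

Measured so far in a functional assay on HepG2 cells (Homo sapiens) for cytotoxicity, read by MTT assay, with a stated time of 72 h; a higher number here means a weaker inhibitor, a lower number a stronger inhibitor:
- compound 1 `Cc1cc(=O)n(-c2cccc(F)c2)nc1C(=O)Nc1ccc(Oc2ncnc3ccsc23)c(F)c1`: 7810 nM
- compound 2 `Cc1ccc(-n2nc(C(=O)Nc3ccc(Oc4ncnc5ccsc45)c(F)c3)c(C)cc2=O)cc1`: 17300 nM
- compound 3 `Cc1cc(=O)n(-c2cccc(F)c2)nc1C(=O)Nc1ccc(Oc2ncnc3sccc23)c(F)c1`: 24500 nM

Compound 1 carries the lowest of the three numbers. Compound 2 differs from compound 1 by the change (4-methylphenyl in place of 3-fluorophenyl on an aromatic nitrogen); the step is a 2.2-fold higher number from compound 1 to compound 2 (0.35 log units; beyond the scatter). Compound 3 differs from compound 1 in the core, as described by a group of 9 heavy atoms (6 carbon, 2 nitrogen, 1 sulfur; one five-membered aromatic ring with 1 hetero atom, one six-membered aromatic ring with 2 hetero atoms) in place of a group of 9 heavy atoms (6 carbon, 2 nitrogen, 1 sulfur; one five-membered aromatic ring with 1 hetero atom, one six-membered aromatic ring with 2 hetero atoms), on an oxygen on an aromatic ring; that step is a 3.1-fold higher number from compound 1 to compound 3 (0.50 log units; beyond the scatter). Compound 2 and compound 3 lie within the usual scatter of each other, so no order between them is drawn.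

Compound 4 `Cc1ccc(-n2nc(C(=O)Nc3ccc(Oc4ncnc5sccc45)c(F)c3)c(C)cc2=O)cc1` is not yet measured. It differs from compound 3 by 4-methylphenyl in place of 3-fluorophenyl on an aromatic nitrogen, and the surroundings of the place are the same in both pairs, so this is the same change that carries compound 1 to compound 2. Within the data shown here, with only one earlier instance of the change, the expectation rests on that single step: compound 4 is expected to sit somewhat higher than compound 3 because of a 2.2-fold higher number from compound 1 to compound 2 (0.35 log units; beyond the scatter), giving an estimated step of a 2.0-fold higher number from compound 3 to compound 4 (0.29 log units; within the scatter). In this assay compound 4 is estimated at 48000 nM, with a range from 20000 nM to 110000 nM.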

Compound 4, half-maximal inhibitory concentration: > 40000 nM
Compound 4: a limit, no number; the forecaster's own chance of this, stated with the estimate: 25%; the middle value is on the limit's open side.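

In this assay compound 4 gives > 40000 nM, which is a limit of the assay and not a number. Placing 4-methylphenyl in place of 3-fluorophenyl on the core of compound 3 gives an at least 1.6-fold higher number from compound 3 to compound 4 (0.21 log units; that floor lies within the scatter), so the number rises on this core as it did on the core of compound 1, but the size of the change on this second core stays unfixed: the same change on two cores in this assay, a 2.2-fold higher number (0.35 log units; beyond the scatter) from compound 1 to compound 2 and an at least 1.6-fold higher number (0.21 log units; that floor lies within the scatter) from compound 3 to compound 4; the limit leaves it open whether they differ The core change, read with 4-methylphenyl in place, gives an at least 2.3-fold higher number from compound 2 to compound 4 (0.36 log units; beyond the scatter), which matches the earlier direction but shows neither that the two changes simply add nor that they interact: the same change on two cores in this assay, a 3.1-fold higher number (0.50 log units; beyond the scatter) from compound 1 to compound 3 and an at least 2.3-fold higher number (0.36 log units; beyond the scatter) from compound 2 to compound 4; the limit leaves it open whether they differ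

As far as these compounds go, how far the number for compound 4 lies past the limit remains open, and with it the true size of both steps. Also open, from the compounds shown here alone, is whether the same direction holds on these two cores for other groups on the aromatic nitrogen, such as a phenyl ring carrying an amine or a carboxylic acid, or a longer chain.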